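The source may hold more compounds than are shown below. What is called first, only, known or untested is meant among the compounds shown, and "the series" means these compounds.

Measured in an assay (strain Wistar) for inhibition of Fatty-acid amide hydrolase 1 (Rattus norvegicus), read by scintillation counting; a lower number here means a stronger inhibitor, a higher number a weaker inhibitor:
compound 1 `CCCNC(=O)Oc1cccc(-c2nc3ncncc3o2)c1` — 4500 nM
compound 2 `O=C(NC1CCCC1)Oc1cccc(C2=NCCO2)c1` — 13 nM
compound 3 `O=C(NC1CCCCC1)Oc1cccc(C2=NCCO2)c1` — 1.2 nM

Compound 2 holds the second highest number of the three: compound 3 lies nearest, compound 1 furthest, at the top. For the measured compounds named here, the one single-point step in the set, an 11-fold lower number from compound 2 to compound 3 (1.03 log units; beyond the scatter), concerns the ring on the carbamate nitrogen and is large.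

Compound 4 `C[C@H]1COC(c2cccc(OC(=O)NC3CCCC3)c2)=N1` differs from compound 2 only by methyl in place of hydrogen on a saturated ring carbon. Going by the values given here, no measured pair probes this position; the step from compound 2 to compound 3 touches another part of the molecule and gives no direct guide. With nothing to anchor a shift, the expected change from compound 2 to compound 4 is small or none beyond the scatter, no change at the digits printed from compound 2 to compound 4 (within the scatter). Compound 4 is therefore estimated at 13 nM in this assay, within 4 nM to 45 nM.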

Compound 4, half-maximal inhibitory concentration: 110 nM
Beside the measured number, compound 4's estimate is 8.5-fold (0.93 log units) below it; the measured number lies above the stated range.
By their numbers in this assay, from the lowest: compound 3; then compound 2; then compound 4; then compound 1.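

In this assay, methyl in place of hydrogen on a saturated ring carbon, next to the ring nitrogen, gives an 8.5-fold higher number from compound 2 to compound 4 (0.93 log units; beyond the scatter). For the compounds shown here, this is the first reading of the five-membered non-aromatic ring, and it shows that this position responds to substitution, with weaker inhibition here. No evidence available bears on the reason for this shift.

Still open, as far as these compounds go, is whether the opposite configuration at this carbon, or an ethyl or hydroxymethyl group in its place, would give a similar number. Also open, from the compounds shown here alone, is whether methyl at this position would shift compound 3 to the same extent.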